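From One Methoxy Group to Two

The source may hold more compounds than are shown below. What is called first, only, known or untested is meant among the compounds shown, and "the series" means these compounds.

In a physicochemical assay for pharmacokinetics, read by HPLC, at pH 7.5, tested at 250 uM (on this read-out lower numbers stand for a shorter-lived compound and higher numbers for a longer-lived compound), compound 1 `Cc1ccc2c(c1)CC(CN(C)C)C2=O` gives 0.4 h, compound 2 `CN(C)CC1Cc2cc(Br)ccc2C1=O` gives 0.1 h and compound 3 `COc1ccc2c(c1)CC(CN(C)C)C2=O` gives 0.75 h. Two steps place compound 3: a 7.5-fold higher number from compound 2 to compound 3 (0.88 log units; beyond the scatter) is beyond the scatter, whereas a 1.9-fold higher number from compound 1 to compound 3 (0.27 log units; within the scatter) stays within it.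

Compound 4 `COc1cc2c(cc1OC)C(=O)C(CN(C)C)C2` carries one further change, (methoxy in place of hydrogen on an aromatic carbon), methoxy in place of hydrogen on an aromatic carbon. Among the measured compounds shown here, no measured step adds a group in place of hydrogen. The closest evidence is the exchange of groups on an aromatic carbon, where methoxy gave a 1.9-fold higher number from compound 1 to compound 3 (0.27 log units; within the scatter) and bromo gave a 4.0-fold lower number from compound 1 to compound 2 (0.60 log units; beyond the scatter). A small upward move is therefore expected, with a 1.3-fold higher number from compound 3 to compound 4 (0.12 log units; within the scatter) estimated to stay within the scatter. The estimate for compound 4 is 1 h, with an expected range of 0.5 h to 2 h.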

Compound 4, half-life: 0.933 h
For compound 4 the middle estimate is 1.1-fold (0.03 log units) above the measured one; the range from low to high includes it.
By their numbers in this assay, from the lowest: compound 2; then compounds 1, 3 and 4 (each within the scatter of the next, the first and the last beyond it).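

Among the compounds shown here, this is the first step here that adds a group in place of hydrogen rather than exchanging one group for another. In this assay a second methoxy on this aromatic carbon, ortho to a methoxy group, gives a 1.2-fold higher number from compound 3 to compound 4 (0.09 log units; within the scatter), so the half-life does not move beyond the scatter with this addition. Nothing available accounts for this result. Still open, from the compounds shown here alone, is whether a hydroxyl, an amine or an ethoxy chain on this carbon would read like methoxy. Also open, going by these compounds, is whether this methoxy would read the same without the first one.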